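The source may hold more compounds than are shown below. What is called first, only, known or untested is meant among the compounds shown, and "the series" means these compounds.

Among the compounds with values here, compound 3 `Cc1ccc(-n2nncc2CN2C(=O)C3(C(C#N)=C(N)Oc4c(N)cc5nc6ccccc6nc5c43)c3ccccc32)cc1Cl` is the only member of this small set that returns an actual number in a functional assay on A549 cells (Homo sapiens) for antiproliferative activity, read by MTT assay, with a stated time of 48 h; on this read-out higher numbers stand for weaker inhibition and lower numbers for stronger inhibition: compound 3 gives 11800 nM. Compound 1 `N#CC1=C(N)Oc2c(N)cc3nc4ccccc4nc3c2C12C(=O)N(Cc1cnnn1-c1ccc(F)cc1)c1ccccc12` returns only a limit in this assay; compound 1 gives > 50000 nM, which is a limit of the assay and not a number. Compound 2 `CCOc1ccccc1-n1nncc1CN1C(=O)C2(C(C#N)=C(N)Oc3c(N)cc4nc5ccccc5nc4c32)c2ccccc21` likewise returns only a limit; compound 2 gives > 50000 nM. The step from compound 1 to compound 2 is a step that the two limits leave unreadable from compound 1 to compound 2. The two steps toward compound 3 can be read only as lower bounds, an at least 4.2-fold lower number from compound 1 to compound 3 (0.62 log units; beyond the scatter) and an at least 4.2-fold lower number from compound 2 to compound 3 (0.62 log units; beyond the scatter), both resting on (the limit of > 50000 nM in this assay, at which 2 of the 3 values shown sit). Compound 4 `N#CC1=C(N)Oc2c(N)cc3nc4ccccc4nc3c2C12C(=O)N(Cc1cnnn1-c1c(Cl)cc(Cl)cc1Cl)c1ccccc12` carries yet another aryl group on the same aromatic nitrogen: 2,4,6-trichlorophenyl in place of 3-chloro-4-methylphenyl on an aromatic nitrogen. Within the data shown here, the measured steps show only that a third aryl group can differ from the first two by a sizeable margin; they give no direction for a fourth aryl group relative to compound 3, so the expectation is centred on compound 3 with wide uncertainty. Compound 4 is expected to sit at about a 1.3-fold higher number from compound 3 to compound 4 (0.10 log units; within the scatter). The estimate for compound 4 is 15000 nM, ranging from 4000 nM to 50000 nM.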

Compound 4, half-maximal inhibitory concentration: > 50000 nM
Compound 4 gave a limit, no number (the forecaster's own chance of this, stated with the estimate: 35%); middle value at least 3.3-fold (0.52 log units) away from the limit.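

In this assay, the change to 2,4,6-trichlorophenyl on the aromatic nitrogen gives an at least 4.2-fold higher number from compound 3 to compound 4 (0.62 log units; beyond the scatter), and this step is only a lower bound, since the value for compound 4 is a limit of the assay and not a number. Chlorine on the aryl group is therefore not enough for a measurable value: compound 3 and compound 4 both carry it, yet among the four aryl groups shown only the 3-chloro-4-methylphenyl group of compound 3 gives a number. The steps among compound 1, compound 2 and compound 4 cannot be read because all three values are limits: the limit of > 50000 nM in this assay, at which 3 of the 4 values shown sit.

The compounds shown leave open whether the chlorine or the methyl of compound 3 matters more. On these data alone, how a plain phenyl, a 3-chlorophenyl or a 4-methylphenyl group would behave on this nitrogen also remains open.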